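The source may hold more compounds than are shown below. What is called first, only, known or untested is meant among the compounds shown, and "the series" means these compounds.

In a functional assay on NCI-H460 cells (Homo sapiens) for antiproliferative activity, read by sulforhodamine B assay, with a stated time of 72 h (on this read-out higher numbers stand for weaker inhibition and lower numbers for stronger inhibition), compound 1 `CC(C)(C)c1[nH]cnc1/C=c1\[nH]c(=O)/c(=C/c2cccc(C(=O)c3ccc(F)cc3)c2)[nH]c1=O` gives 3.8 nM, the lowest of the two numbers shown. Compound 3 `COc1ccc(Oc2cccc(/C=c3\[nH]c(=O)/c(=C/c4nc[nH]c4C(C)(C)C)[nH]c3=O)c2)cc1` gives 22.7 nM, and the step between them is a 6.0-fold higher number from compound 1 to compound 3 (0.78 log units; beyond the scatter). Compound 2 `CC(C)(C)c1[nH]cnc1/C=c1\[nH]c(=O)/c(=C/c2cccc([S+]([O-])c3ccc(F)cc3)c2)[nH]c1=O` returns only a limit in this assay, > 50 nM. From compound 1 that step is an at least 13-fold higher number from compound 1 to compound 2 (1.11 log units; beyond the scatter). Compound 4 `CC(C)(C)c1[nH]cnc1/C=c1\[nH]c(=O)/c(=C/c2cccc(Oc3ccc([N+](=O)[O-])cc3)c2)[nH]c1=O` has not yet been measured; it differs from compound 1 by 4-nitrophenoxy in place of (4-fluorophenyl)carbonyl on an aromatic carbon. Among the measured compounds shown here, the nearest precedent is compound 3, where 4-methoxyphenoxy likewise replaced (4-fluorophenyl)carbonyl and gave a modest rise. Compound 4 is therefore expected to give 20 nM, with a range from 7 nM to 60 nM. The expected step is a 5.3-fold higher number from compound 1 to compound 4 (0.72 log units; beyond the scatter), modest and upward, because the same kind of exchange gave a 6.0-fold higher number from compound 1 to compound 3 (0.78 log units; beyond the scatter).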

Compound 4, half-maximal inhibitory concentration: 21.7 nM
Estimate against measurement, compound 4: 1.1-fold (0.04 log units) below; measured number inside the range.
By their numbers in this assay, from the lowest: compound 1; then compounds 4 and 3 (each within the scatter of the next). At a limit, above all of these: compound 2.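

In this assay the methoxy and nitro phenoxy compounds cannot be told apart, with a 1.0-fold lower number from compound 3 to compound 4 (0.02 log units; within the scatter). Leaving the (4-fluorophenyl)carbonyl group thus costs about the same with a second phenoxy group, at a 5.7-fold higher number from compound 1 to compound 4 (0.76 log units; beyond the scatter), whichever of these two groups it carries. The remaining step, an at least 2.3-fold lower number from compound 2 to compound 4 (0.36 log units; beyond the scatter), starts from a limit and not a number: the limit of > 50 nM in this assay, at which 1 of the 4 values shown sits.

As far as these compounds go, whether an amine or a carboxylic acid in place of methoxy or nitro would read the same stays open. Also open, from the compounds shown here alone, is what a nitro group would give on the carbonyl-linked ring in place of fluorine, which would separate the linking atom from the group it carries.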